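Removal of the carboxy group from compound 2

The source may report more compounds than this note shows. Statements on the series, on what has been measured and on what is new or still open speak of the compounds shown alone.

Measured so far:
- compound 1 `COCC(=N)NCCCCN`: 983000 nM
- compound 2 `COCCC(=N)NCCC[C@H](N)C(=O)O`: 9000 nM

In an assay on cells for inhibition of N(G),N(G)-dimethylarginine dimethylaminohydrolase 1 (Homo sapiens), with a stated time of 30 min (on this read-out lower numbers stand for stronger inhibition and higher numbers for weaker inhibition), compound 2 gives 9000 nM, the lowest of the two numbers in hand. In this assay compound 1 gives 983000 nM, a much higher number; the gap between the two is beyond the scatter, but the two differ in more than one place, so no single change can be read from it.

Compound 3 `COCCC(=N)NCCCCN` has not been measured in this assay. It differs from compound 2 by hydrogen in place of carboxy on a saturated chain carbon bound to an amine nitrogen and a saturated chain carbon. Among the measured compounds shown here, no measured pair carries this change on its own. With only compound 1 and compound 2 as anchors, and compound 1 at 983000 nM also lacking the carboxy group, the step of a 33-fold higher number from compound 2 to compound 3 (1.52 log units; beyond the scatter) is expected to be large and toward weaker inhibition. For compound 3 in this assay the estimate is 300000 nM, with an expected range from 50000 nM to 1500000 nM.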

Compound 3, inhibition constant: 1450000 nM
Estimate against measurement, compound 3: 4.8-fold (0.68 log units) below; measured number inside the range.
By their numbers in this assay, from the lowest: compound 2; then compounds 1 and 3 (each within the scatter of the next).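

In this assay, the carboxy group on a saturated chain carbon bound to an amine nitrogen and a saturated chain carbon now has a step of its own: hydrogen in its place gives a 160-fold higher number from compound 2 to compound 3 (2.21 log units; beyond the scatter), a large loss of inhibition. Among the compounds lacking the carboxy group, methoxymethyl in place of methoxy gives a 1.5-fold higher number from compound 1 to compound 3 (0.17 log units; within the scatter), so this change has no readable effect on that background, where both numbers remain high. Nothing on hand explains the size of the carboxy step.

From the compounds shown here alone, whether a methyl ester, a primary amide or a tetrazole could stand in for the carboxy group and keep the number of compound 2 remains open. So does the effect of methoxy in place of methoxymethyl with the carboxy group present, or of an ethoxy group at that end.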